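From Vinyl to Aryl Ketone on an Inactive Sulfur Chain

A few compounds are considered here, and "the series" means these few. Any claim that something is new, unique, unknown or untested is made for them only; others in the source may bear on it.

In a functional assay on A549 cells (Homo sapiens) for cytotoxicity, read by MTT assay, with a stated time of 48 h (a lower number here means a stronger inhibitor, a higher number a weaker inhibitor), the measured compounds stand as follows:
Compound 1, `C=CCSc1nnc(CC)n1N1C(=O)c2ccccc2C1=O`, gives only the limit > 200000 nM.
Compound 2, `CCc1nnc(SCC(=O)c2ccccc2)n1N1C(=O)c2ccccc2C1=O`, gives only the limit > 200000 nM.
Compound 3, `C=CCSc1nnc(CCC)n1N1C(=O)c2ccccc2C1=O`, gives only the limit > 200000 nM.

None of the three compounds reaches a number: every value is a limit of this assay, as the line the limit of > 200000 nM in this assay, at which 3 of the 3 values shown sit, sums up. Compound 3 therefore stands with the other two, and no order among them can be read.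

Compound 4, `CCCc1nnc(SCC(=O)c2ccc(C)cc2)n1N1C(=O)c2ccccc2C1=O`, differs from compound 3 in one place: (4-methylphenyl)carbonyl in place of vinyl on a saturated chain carbon bound to a sulfur. Going by the values given here, two measured steps touch this change. The step that the two limits leave unreadable from compound 1 to compound 2 swaps vinyl for benzoyl at the same place, a close relative of the present change, and the step that the two limits leave unreadable from compound 1 to compound 3 connects the two chain lengths on the shared core; both steps remain unreadable because their ends sit at the limit of > 200000 nM in this assay, at which 3 of the 3 values shown sit.

Since the closest measured step, from compound 1 to compound 2, left both compounds at the limit, compound 4 is expected to stay at the limit as well, with a step that the limit leaves unreadable from compound 3 to compound 4 that cannot be distinguished from none. The estimate for compound 4 in this assay is 300000 nM, with a range from 100000 nM to 1000000 nM.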

Compound 4, half-maximal inhibitory concentration: > 200000 nM
Compound 4: no number, only a limit; the forecaster's own chance of this, stated with the estimate: 85%; the middle value does not contradict the limit.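

In this assay compound 4 gives > 200000 nM as a limit and not a number. No step can be read between compound 3 and compound 4, since both sit at the same limit: the limit of > 200000 nM in this assay, at which 4 of the 4 values shown sit.

The compounds shown leave open how these four would rank in this assay and whether any change on the shared core would give a measurable value.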